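Amine substituent change from compound 2 to compound 3

A few compounds are considered here, and "the series" means these few. Any claim that something is new, unique, unknown or untested is made for them only; others in the source may bear on it.

Compound 1 `COc1cc(Oc2cccc(Nc3ccccc3)c2)cc(OC)c1CNC1CC1` carries cyclopropyl on the amine nitrogen. In a functional assay on HCT-116 cells (Homo sapiens) for inhibition, read by MTT assay, with a stated time of 72 h (on this read-out lower numbers stand for stronger inhibition and higher numbers for weaker inhibition), compound 1 gives only the limit > 20000 nM. Compound 2 `COc1cc(Oc2cccc(Nc3ccccc3)c2)cc(OC)c1CNC(C)C` carries isopropyl in that place. In this assay compound 2 likewise gives only the limit > 20000 nM. The step that the two limits leave unreadable from compound 1 to compound 2 is unreadable, both values sitting at the limit of > 20000 nM in this assay, at which 2 of the 2 values shown sit. Compound 3 `COc1ccc(CNCc2c(OC)cc(Oc3cccc(Nc4ccccc4)c3)cc2OC)cc1` differs from compound 2 by 4-methoxybenzyl in place of isopropyl on an amine nitrogen. Within the data shown here, no measured step bears on this change, and the two limits set no direction or size. Compound 3 is expected to give 15000 nM (range 3000 nM to 60000 nM), the estimated step of an at least 1.3-fold lower number from compound 2 to compound 3 (0.12 log units; that floor lies within the scatter) carrying most weight on a further limit.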

Compound 3, half-maximal inhibitory concentration: 2620 nM
Compound 3: the middle estimate sits 5.7-fold (0.76 log units) above what was measured; the whole stated range lies above it.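

This position on the amine nitrogen does respond in this assay: 4-methoxybenzyl gives an at least 7.6-fold lower number from compound 2 to compound 3 (0.88 log units; beyond the scatter) and an at least 7.6-fold lower number from compound 1 to compound 3 (0.88 log units; beyond the scatter) and brings the first measured number into the series. Compound 1 and compound 2 stand at limits, so both steps are floors and not full sizes. The step between those two compounds cannot be read.

On these data alone, it remains open whether plain benzyl, without the methoxy, or a longer chain such as phenethyl on the same nitrogen would keep this gain. The compounds shown also leave open what a 4-chlorobenzyl group would do there.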